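From 2-Ethoxypyrimidin-5-yl to 6-Ethoxypyridin-3-yl

The compounds below may be only part of what the source reports. "The series", "measured", "known", "first", "only" and "open" are said of these compounds alone.

Compound 1 `CCOc1ncc(-c2nc(C(F)(F)F)sc2N2CCN(C(=O)Cn3c(=O)oc4ccccc43)[C@H](C)C2)cn1` gives 536 nM in an assay on blood for inhibition of C-X-C chemokine receptor type 3 (Homo sapiens), with a stated time of 30 min; on this read-out higher numbers stand for weaker inhibition and lower numbers for stronger inhibition.
Compound 2 `CCOc1ncc(-c2nc(C(F)(F)F)sc2N2CCN(C(=O)Cn3nccc3C)[C@H](C)C2)cn1` gives 289 nM in this assay.
Compound 3 `CCOc1ncc(-c2nc(C(F)(F)F)sc2N2CCN(C(=O)Cn3nc(C)nc3C)[C@H](C)C2)cn1` gives 364 nM in this assay.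

The three measured compounds share a core and differ only in the group on a saturated chain carbon bound to a carbonyl carbon. Compound 3 holds the second highest of the three numbers; its nearest neighbour is compound 2, with a 1.3-fold higher number from compound 2 to compound 3 (0.10 log units; within the scatter), and its furthest is compound 1, with a 1.5-fold lower number from compound 1 to compound 3 (0.17 log units; within the scatter). Neither gap exceeds the scatter, so the three numbers cannot be told apart.

Compound 4 `CCOc1ccc(-c2nc(C(F)(F)F)sc2N2CCN(C(=O)Cn3nc(C)nc3C)[C@H](C)C2)cn1` leaves that side of the molecule untouched and alters the core instead: 6-ethoxypyridin-3-yl in place of 2-ethoxypyrimidin-5-yl on an aromatic carbon. For the measured compounds named here, no measured step bears on this position. The steps that exist, a 1.9-fold lower number from compound 1 to compound 2 (0.27 log units; within the scatter) and the two gaps above, all sit on the other side of the molecule and all stayed within the scatter, so they give no guide to the direction of this change. With nothing pointing either way, a 1.0-fold lower number from compound 3 to compound 4 (0.00 log units; within the scatter) is expected to stay within the scatter. The estimate for compound 4 in this assay is 360 nM, within a range from 150 nM to 900 nM.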

Compound 4, half-maximal inhibitory concentration: 887 nM
Beside the measured number, compound 4's estimate is 2.5-fold (0.39 log units) below it, within the range that was stated.
By their numbers in this assay, from the lowest: compounds 2, 3, 1 and 4 (each within the scatter of the next, the first and the last beyond it).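

With 6-ethoxypyridin-3-yl in place of 2-ethoxypyrimidin-5-yl, this assay shows a 2.4-fold higher number from compound 3 to compound 4 (0.39 log units; beyond the scatter), a modest step towards weaker inhibition. It is the only step among these compounds that goes beyond the scatter, so the group on this aromatic carbon matters more here than the groups exchanged on the saturated chain carbon, whose steps all stayed within it. The two groups have the same count of heavy atoms and differ by one ring nitrogen exchanged for carbon, yet nothing available explains why this exchange weakens inhibition.

This single pair leaves open whether the same exchange would weaken inhibition with 5-methyl-1H-pyrazol-1-yl on the saturated chain carbon. Also open, going by these compounds, is how this assay would respond to a methoxy group or an amine in place of the ethoxy group on either ring.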